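From thiophen-2-yl to ethynyl on a shared core

The compounds below may be only part of what the source reports. "The series", "measured", "known", "first", "only" and "open" are said of these compounds alone.

In an ADME assay on BJ cells (Homo sapiens), read by MTT assay, with a stated time of 72 h (on this read-out higher numbers stand for weaker inhibition and lower numbers for stronger inhibition), compound 3 (`Cc1nc(N)c2c(-c3cccs3)cn([C@@H]3O[C@H](CO)[C@@H](O)[C@H]3O)c2n1`) gives > 100000 nM as a limit and not a number. Compound 1 (`Cc1ncnc2c1c(-c1cccs1)cn2[C@@H]1O[C@H](CO)[C@@H](O)[C@H]1O`) gives > 100000 nM as a limit too. Compound 2 (`Nc1nc(N)c2c(-c3cccs3)cn([C@@H]3O[C@H](CO)[C@@H](O)[C@H]3O)c2n1`) gives > 100000 nM as a limit too. The series therefore stands at the limit of > 100000 nM in this assay, at which 3 of the 3 values shown sit, and offers no number to start from. Compound 4 (`C#Cc1cn([C@@H]2O[C@H](CO)[C@@H](O)[C@H]2O)c2nc(C)nc(N)c12`) carries ethynyl in place of thiophen-2-yl on an aromatic carbon and so leaves the group that all three measured compounds share. Going by the values given here, the one measured step is a step that the two limits leave unreadable from compound 2 to compound 3 and it concerns methyl in place of amino, so it does not bear on this change in size. The expected move, an at least 1.6-fold lower number from compound 3 to compound 4 (0.22 log units; that floor lies within the scatter), is uncertain and could be read only toward stronger inhibition. Compound 4 is estimated at 60000 nM in this assay, with an expected range from 3000 nM to 100000 nM and a real chance of another limit.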

Compound 4, half-maximal inhibitory concentration: > 100000 nM
Compound 4: a limit, no number; the forecaster's own chance of this, stated with the estimate: 60%; at least 1.6-fold (0.22 log units) between middle value and limit.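

Compound 4 gives > 100000 nM in this assay, a limit and not a number, so the step from compound 3 to compound 4 cannot be read. The compounds shown leave open what change on the shared core would bring a measurable number, as all stand at one limit: the limit of > 100000 nM in this assay, at which 4 of the 4 values shown sit.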